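Compound 3 to compound 4: methylamino to anilino

A few compounds are considered here, and "the series" means these few. Any claim that something is new, unique, unknown or untested is made for them only; others in the source may bear on it.

Values so far in a physicochemical assay for lipophilicity, at pH 7.4 (a higher number here means a more lipophilic compound, a lower number a more polar compound), are these.
- Compound 1 `O=C(NC1CC1)C1CCN(c2cnccc2-c2ccccc2)CC1` gives 2.5 on this scale.
- Compound 2 `O=C(NC1CC1)C1CCN(c2cnccc2-c2ccccn2)CC1` gives 1.3 on this scale.
- Compound 3 `CNC(=O)C1CCN(c2cncnc2-c2ccccc2)CC1` gives 1.4 on this scale.

Compound 3 lies within the scatter of compound 2, while compound 1 stands above both, beyond the scatter. Compound 4 `O=C(Nc1ccccc1)C1CCN(c2cncnc2-c2ccccc2)CC1` has not yet been measured. The change from compound 3, phenyl in place of methyl on an amide-type nitrogen, is phenyl in place of methyl on an amide-type nitrogen and it turns methylcarbamoyl into phenylcarbamoyl.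

Among the measured compounds shown here, no measured step makes this change. For the measured compounds named here, the only measured step is a number 1.20 log units lower from compound 1 to compound 2 (beyond the scatter) and it is a large one, but it concerns pyridin-2-yl in place of phenyl on an aromatic carbon. It therefore bears only indirectly, as a guide to how far the exchange of one aromatic ring can move the number. On that guide, and with a ring of carbon only entering, a higher number of similar or somewhat greater size is expected, a number 1.50 log units higher from compound 3 to compound 4 (beyond the scatter) in this assay and so beyond the scatter. Compound 4 is estimated at 2.9 with an expected range from 2.3 to 3.5 for the measurement.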

Compound 4, distribution coefficient: 2.7
The estimate for compound 4 lay 0.20 log units above the measured number; the measured number falls inside the stated range.
By their numbers in this assay, from the lowest: compounds 2 and 3 (each within the scatter of the next); then compounds 1 and 4 (each within the scatter of the next).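

At this place, on an amide-type nitrogen whose other neighbour is the carbonyl carbon, phenyl in place of methyl moves the number in this assay by a large amount: a number 1.30 log units higher from compound 3 to compound 4 (beyond the scatter). Among the compounds shown here, this is the first measured change at this nitrogen, since the only earlier step concerned an exchange on an aromatic carbon, and it shows that a change here can also shift the number well beyond the scatter, even though neither the leaving nor the entering group counts any hydrogen-bond donor, hydrogen-bond acceptor or net charge. Nothing available explains the size of this step, so it stands as an observation only.

For the compounds shown here, the single pair cannot separate the contribution of the aromatic ring from that of the added carbon atoms, and a butyl chain or a benzyl group on the same nitrogen would be needed to tell them apart. On these data alone, it also remains open whether an aminomethyl or carboxylic acid group on the entering phenyl would bring the number back down, and whether the same exchange would give a similar step on the core of compound 1.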